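Swapping a sulfur-bearing bicyclic group for a substituted phenoxy ring

The source may hold more compounds than are shown below. What is called first, only, known or untested is meant among the compounds shown, and "the series" means these compounds.

Compound 1 `CCOC(=O)c1c(-c2ccccc2)nn(-c2ccccc2)c1Cn1c(S)nc2ccccc21` was tested in an assay for inhibition of Alpha amylase (Homo sapiens), with a stated time of 30 min (a lower number here means a stronger inhibitor, a higher number a weaker inhibitor), where compound 1 gives 40 ug/mL. Compound 2 `CCOC(=O)c1c(-c2ccccc2)nn(-c2ccccc2)c1Cn1cnc2ccccc21` gives 35 ug/mL and compound 3 `CCOC(=O)c1c(-c2ccccc2)nn(-c2ccccc2)c1COc1ccccc1C=O` gives 40 ug/mL; all three numbers sit within the usual scatter of one another, so compound 1 stands level with compound 3 and no ordering can be read from them. Compound 4 `CCOC(=O)c1c(-c2ccccc2)nn(-c2ccccc2)c1COc1ccc(C=O)cc1OC` differs from compound 1 by a group of 11 heavy atoms (8 carbon, 3 oxygen; one six-membered aromatic ring of carbon only) in place of a group of 10 heavy atoms (7 carbon, 2 nitrogen, 1 sulfur; one five-membered aromatic ring with 2 hetero atoms, one six-membered aromatic ring of carbon only), on a saturated chain carbon bound to an aromatic carbon. The closest measured comparison is the related exchange at the same position, no change at the digits printed from compound 1 to compound 3 (within the scatter), and the step of a 1.1-fold higher number from compound 2 to compound 3 (0.06 log units; within the scatter) was also flat. The shared core therefore appears to tolerate different groups at this chain carbon, and for compound 4 no shift beyond the scatter is expected, no change at the digits printed from compound 1 to compound 4 (within the scatter). Compound 4 is estimated at 40 ug/mL, expected between 20 ug/mL and 80 ug/mL.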

Compound 4, half-maximal inhibitory concentration: 60 ug/mL
Compound 4: middle estimate off by 1.5-fold (0.18 log units), on the low side; the range from low to high includes it.
By their numbers in this assay, from the lowest: compounds 2, 1, 3 and 4 (each within the scatter of the next).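

The 4-formyl-2-methoxyphenoxy group on this saturated chain carbon reads level with the group in compound 1 (a 1.5-fold higher number from compound 1 to compound 4 (0.18 log units; within the scatter)), with 2-formylphenoxy (a 1.5-fold higher number from compound 3 to compound 4 (0.18 log units; within the scatter)) and with 1H-benzimidazol-1-yl (a 1.7-fold higher number from compound 2 to compound 4 (0.23 log units; within the scatter)). Adding a methoxy group to the phenoxy ring and giving the formyl group a different printed position therefore opens no gap beyond the scatter, so none of the four groups stands apart. No supporting measurement bears on why these groups read alike.

On these data alone, all four groups contain an aromatic ring, so it remains open whether an amine, a carboxylic acid or a plain longer chain at this carbon would shift the number.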